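Volume of distribution in the series: cyclopropyl to oxolan-3-yl

The compounds below may be only part of what the source reports. "The series", "measured", "known", "first", "only" and "open" are said of these compounds alone.

Compound 1 `CCn1c(-c2cnc(C)nc2)nc2c(O[C@H]3CCN(C(=O)C4CC4)C3)ncnc21` sets the low end of the three numbers recorded in an ADME assay (Rattus norvegicus, strain Wistar Han) for pharmacokinetics; a lower number here means that more of the compound stays in the plasma, a higher number that more of the compound sits outside the plasma: compound 1 gives 2.8 L/kg. Within the data shown here, compound 3 `CCn1c(-c2ccc(C(F)(F)F)nc2)nc2c(O[C@H]3CCN(C(=O)C4CC4)C3)ncnc21` gives 8.3 L/kg in this assay, and the one change between them, 6-(trifluoromethyl)pyridin-3-yl in place of 2-methylpyrimidin-5-yl on an aromatic carbon, gives a 3.0-fold higher number from compound 1 to compound 3 (0.47 log units; beyond the scatter). Compound 2 `CCn1c(-c2cnc(C)nc2)nc2c(N[C@H]3CCN(C(=O)C4CC(F)(F)C4)C3)ncnc21` gives 18 L/kg; it differs from compound 1 in more than one place, so its number is only a point of reference.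

Compound 4 `CCn1c(-c2cnc(C)nc2)nc2c(O[C@H]3CCN(C(=O)C4CCOC4)C3)ncnc21` is not yet measured. It differs from compound 1 in one place: oxolan-3-yl in place of cyclopropyl on a carbonyl carbon. Among the measured compounds shown here, none of the measured steps touches the group on the carbonyl carbon, so the only recorded step, that from compound 1 to compound 3, concerns a different part of the structure and does not carry over. For compound 4 the expectation is therefore a number near that of compound 1, with the step of a 1.2-fold lower number from compound 1 to compound 4 (0.09 log units; within the scatter) expected to stay within the usual scatter. Compound 4 is estimated at 2.3 L/kg, within a range of 1.2 L/kg to 4.5 L/kg.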

Compound 4, volume of distribution: 0.9 L/kg
The estimate for compound 4 lay 2.6-fold (0.41 log units) above the measured number; measured number below the stated range.
By their numbers in this assay, from the lowest: compound 4; then compound 1; then compound 3; then compound 2.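

The group on the carbonyl carbon is a place that moves the number in this assay: oxolan-3-yl in place of cyclopropyl gives a 3.1-fold lower number from compound 1 to compound 4 (0.49 log units; beyond the scatter). This step runs opposite in direction to a 3.0-fold higher number from compound 1 to compound 3 (0.47 log units; beyond the scatter), so two separate places on compound 1 each shift the read-out beyond the scatter. The entering group carries one hydrogen-bond acceptor where cyclopropyl carries none, but ring size and ring content change together, and nothing measured here accounts for the step.

Still open, as far as these compounds go, is whether the lower number goes with the ring oxygen or the larger ring, which cyclopentyl or oxetan-3-yl on the same carbonyl carbon would help separate. Also open, from the compounds shown here alone, is whether oxolan-3-yl gives a similar step alongside the 6-(trifluoromethyl)pyridin-3-yl group of compound 3.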